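The compounds below may be only part of what the source reports. "The series", "measured", "known", "first", "only" and "open" are said of these compounds alone.

Of the compounds shown here, three of one shared core have been measured in a functional assay on U-251 cells (Homo sapiens) for inhibition, read by colony formation, with stated times of 48 h and 2 weeks, tested at 10 uM; a higher number here means more inhibition at the concentration tested (going by the name of the read-out), a lower number less inhibition. Compound 1 `O=C(/C=C/c1c[nH]c2ccccc12)c1ccccn1` carries no substituent on the oxygen-bearing ring position, and in this assay compound 1 gives 53%. Compound 2 `COc1ccc2[nH]cc(/C=C/C(=O)c3ccncc3)c2c1` gives 2%, and compound 3 `O=C(/C=C/c1c[nH]c2ccc(OCc3ccccc3)cc12)c1ccncc1` gives 8%. Compound 2 thus stands lowest of the three numbers, with compound 3 closest, a gap within the scatter, and compound 1 furthest, well beyond the scatter. Compound 1 differs from compound 2 in more than one place, so its value can only be read as a contrast and not as a single step.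

Compound 4 `O=C(/C=C/c1c[nH]c2ccc(O)cc12)c1ccncc1` is the next compound to be examined in this assay. It differs from compound 2 in one place: hydrogen in place of methyl on an oxygen on an aromatic ring. Among the compounds with values here, the one measured step that touches the same oxygen is a number 6 percentage points higher from compound 2 to compound 3 (within the scatter), where a phenyl replaced hydrogen on a saturated chain carbon bound to that oxygen without moving the number beyond the scatter. Within the data shown here, no step in hand removes the methyl itself. On that basis a step of a number 6 percentage points higher from compound 2 to compound 4 (within the scatter) is expected, that is, nothing beyond the scatter. Compound 4 is therefore estimated at 8%, within a range from 0% to 30%.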

Compound 4, a percentage reported as inhibition, at one concentration (the size of the read-out at that concentration, not a potency): 72%
Compound 4: middle estimate off by 64 percentage points, on the low side, outside the stated range (above it).
By their numbers in this assay, from the lowest: compounds 2 and 3 (each within the scatter of the next); then compound 1; then compound 4.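

In this assay, the oxygen on an aromatic ring proves to be a place where the number can change sharply, but only with one particular change: methoxy to hydroxy gives a number 70 percentage points higher from compound 2 to compound 4 (beyond the scatter), and hydrogen in place of benzyl gives a number 64 percentage points higher from compound 3 to compound 4 (beyond the scatter). The earlier step had shown only that methyl and benzyl on this oxygen lie within the scatter of each other, which said nothing about what the oxygen does with neither group on it. Among compound 2, compound 3 and compound 4, then, the large difference separates the hydroxy compound from both capped compounds, and nothing in hand explains this difference.

The compounds shown leave open whether an amine or a carboxylic acid at this place would keep the high number of compound 4, and whether any small group on the oxygen, such as ethyl, would already lose it. They also leave open what a hydroxy would do on the core of compound 1, which gives 53% without this oxygen but differs from compound 4 in more than one place, so that no single step can be read from that pair.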